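Trifluoromethoxy for trifluoromethyl at a second ring position

A few compounds are considered here, and "the series" means these few. Any claim that something is new, unique, unknown or untested is made for them only; others in the source may bear on it.

Measured so far:
- compound 1, `Oc1nc2nonc2nc1Nc1ccccc1C(F)(F)F`: 10600 nM
- compound 2, `Oc1nc2nonc2nc1Nc1cccc(C(F)(F)F)c1`: 13300 nM
- compound 3, `Oc1nc2nonc2nc1Nc1ccccc1OC(F)(F)F`: 7100 nM

All three were tested in an assay on mitochondria from L6 cells (Rattus norvegicus) for activation, with a stated time of 90 min; on this read-out lower numbers stand for an effect already at smaller amounts and higher numbers for an effect only at larger amounts of compound. Compound 1 and compound 2 are built from the same atoms joined differently; the difference between the two cores is not broken down here. Compound 3 carries trifluoromethoxy in place of trifluoromethyl on an aromatic carbon, and that change gave a 1.5-fold lower number from compound 1 to compound 3 (0.17 log units; within the scatter).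

Compound 4, `Oc1nc2nonc2nc1Nc1cccc(OC(F)(F)F)c1`, has not yet been measured in this assay. It carries trifluoromethoxy in place of trifluoromethyl on an aromatic carbon. The place line differs: in compound 3 the new group sits ortho to a large group, in compound 4 meta to a large group, so this is the same kind of change, not the same one. The expected step is a 1.5-fold lower number from compound 2 to compound 4 (0.17 log units; within the scatter), beside the measured 1.5-fold lower number from compound 1 to compound 3 (0.17 log units; within the scatter), because a 1.5-fold lower number from compound 1 to compound 3 (0.17 log units; within the scatter) stayed within the scatter. Compound 4 is therefore expected to give 9000 nM. For compound 4 the estimate is expected to lie between 4000 nM and 20000 nM.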

Compound 4, half-maximal effective concentration: 5100 nM
Compound 4: the middle estimate sits 1.8-fold (0.25 log units) above what was measured; the range from low to high includes it.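

In this assay, putting trifluoromethoxy in place of trifluoromethyl gave a 2.6-fold lower number from compound 2 to compound 4 (0.42 log units; beyond the scatter). Set beside the earlier step, the change gives steps on the two cores that cannot be told apart: the same change on two cores in this assay, a 1.5-fold lower number (0.17 log units; within the scatter) from compound 1 to compound 3 and a 2.6-fold lower number (0.42 log units; beyond the scatter) from compound 2 to compound 4, 1.7-fold (0.24 log units) apart, within the scatter of two such steps. This shows that the size of the step held across these two pairs, but only the second step lies beyond the scatter, and two pairs cannot show that the change would behave the same way on any other core of the series.

The compounds shown leave open what other groups on the same aromatic ring, such as an amine, a carboxylic acid or a longer chain, would do to the number. They also leave open why the two groups differ at all.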